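The source may report more compounds than this note shows. Statements on the series, on what has been measured and on what is new or still open speak of the compounds shown alone.

Compound 1 `CC(=O)O[C@@H]1OC(=O)[C@@](C(C)=O)(C2SCCCS2)[C@@H]1C` is tested in a functional assay on B16 cells (Mus musculus) for cytotoxicity, read by MTT assay (on this read-out lower numbers stand for stronger inhibition and higher numbers for weaker inhibition), and returns only a limit, > 50000 nM; no number is known for it, so its standing rests on (the limit of > 50000 nM in this assay, at which 2 of the 3 values shown sit). Compound 2 `CC(=O)O[C@@H]1OC(=O)[C@](C)(C(C)=O)[C@@H]1C(C)C` likewise returns a limit in this assay, > 50000 nM. Compound 3 `CC(=O)O[C@@H]1OC(=O)[C@@](C)(C(C)=O)[C@@H]1C` gives a number in this assay, 14000 nM. Going by the values given here, no pair of measured compounds differs in a single place, so no measured step is available to carry over to the open case. The change from compound 1 to compound 4 `CC(=O)O[C@@H]1OC(=O)[C@@H](C(C)=O)[C@@H]1C` is a hydrogen atom in place of a group of 6 heavy atoms (4 carbon, 2 sulfur; one six-membered non-aromatic ring with 2 hetero atoms), on a saturated ring carbon. Compound 3 carries a methyl group at that carbon of the shared core and gives a number, while compound 1 and compound 2 both sit at the limit. Because compound 1 sits at the limit of > 50000 nM in this assay, at which 2 of the 3 values shown sit, a step away from it can only be stated as downward or as none. The expected step of an at least 1.6-fold lower number from compound 1 to compound 4 (0.22 log units; that floor lies within the scatter) is toward a measurable value, with the range held wide. Compound 4 is expected at 30000 nM, between 8000 nM and 100000 nM.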

Compound 4, half-maximal inhibitory concentration: > 50000 nM
Compound 4: a limit, no number; the forecaster's own chance of this, stated with the estimate: 40%; middle value at least 1.6-fold (0.22 log units) away from the limit.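

Compound 1 and compound 4 both return only a limit in this assay, and no step between them can be read: the limit of > 50000 nM in this assay, at which 3 of the 4 values shown sit.

The compounds shown leave open whether a hydrogen atom in place of the group of 6 heavy atoms changes the read-out at all, as neither compound has a number.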